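Chloro for Methoxy: Cytotoxicity Expected to Stay Absent

The compounds below may be only part of what the source reports. "The series", "measured", "known", "first", "only" and "open" are said of these compounds alone.

Going by the values given here, the three compounds measured so far share one core: compound 1 `C=C[C@@](C)(/C=C/c1ccc(O)cc1)CC/C=C(\C)CO`, compound 2 `C=C[C@@](C)(/C=C/c1ccc(O)c(/C=C/C#N)c1)CCC=C(C)C` and compound 3 `C=C[C@@](C)(/C=C/c1ccc(Nc2ccc(OC)cc2)cc1)CCC=C(C)C`. In an ADME assay on BJ cells (Homo sapiens) for cytotoxicity, with a stated time of 72 h (on this read-out higher numbers stand for an effect only at larger amounts of compound and lower numbers for an effect already at smaller amounts), compound 1 gives > 36600 nM, which is a limit of the assay rather than a number. Compound 2 likewise reaches only a limit in this assay, > 36600 nM. Compound 3 also sits at a limit, > 36600 nM. Thus the limit of > 36600 nM in this assay, at which 3 of the 3 values shown sit: none of the three shows a toxic effect within the concentrations tested, and compound 3 stands exactly where every other measured compound stands.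

Compound 4 `C=C[C@@](C)(/C=C/c1ccc(Nc2ccc(Cl)cc2)cc1)CCC=C(C)C` differs from compound 3 in one place: chloro in place of methoxy on an aromatic carbon. Among the compounds with values here, no measured pair shows what this exchange does in this assay. With every measured compound at the same limit, the change is expected to bring no step beyond the scatter, so the expected step that the limit leaves unreadable from compound 3 to compound 4 is essentially none. Compound 4 is therefore estimated at 40000 nM, within a range from 15000 nM to 100000 nM, and this assay is expected most likely to report only a limit again.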

Compound 4, half-maximal effective concentration: > 36600 nM
Compound 4 gave a limit, no number; the forecaster's own chance of this, stated with the estimate: 75%; the middle value lies beyond the limit too.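

No step can be read from compound 3 to compound 4, because both stop at the same limit: the limit of > 36600 nM in this assay, at which 4 of the 4 values shown sit.

The compounds shown leave open at what concentration, if any, each would harm these cells, and whether chloro in place of methoxy changes that concentration.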